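Swapping fluoro for methoxy on the aryl ring of compound 1

The compounds below may be only part of what the source reports. "The series", "measured", "known", "first", "only" and "open" are said of these compounds alone.

Measured compounds:
- compound 1, `Fc1ccc(-c2nc(-c3c[nH]c4ccccc34)co2)cc1`: 59800 nM
- compound 2, `c1ccc2c(-c3coc(-c4ccncc4)n3)c[nH]c2c1`: 238000 nM

Both compounds were tested in a functional assay on LNCaP cells (Homo sapiens) for cytotoxicity, read by MTT assay, with a stated time of 48 h; a higher number here means a weaker inhibitor, a lower number a stronger inhibitor. Compound 1 gives 59800 nM, the lower of the two numbers. Compound 2 gives 238000 nM. Within the data shown here, the single measured step, a 4.0-fold higher number from compound 1 to compound 2 (0.60 log units; beyond the scatter), replaces the whole 4-fluorophenyl ring with a pyridin-4-yl ring.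

Among the measured compounds shown here, compound 3, `COc1ccc(-c2nc(-c3c[nH]c4ccccc34)co2)cc1`, keeps the shared core and the aryl ring of compound 1 and changes only one group on it: methoxy in place of fluoro on an aromatic carbon. The step from compound 1 to compound 2 is the only one available, and it concerns a different kind of change, a ring swap rather than a small group on a ring, so it offers only loose guidance. For the measured compounds named here, with no measured step for a methoxy-for-fluoro exchange, the expectation for compound 3 is a small movement, likely within the scatter of this assay.

Compound 3 is therefore expected to give about 50000 nM, with a plausible range from 20000 nM to 150000 nM. The estimated step of a 1.2-fold lower number from compound 1 to compound 3 (0.08 log units; within the scatter) is expected to lie within the usual scatter.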

Compound 3, half-maximal inhibitory concentration: 507000 nM
Beside the measured number, compound 3's estimate is 10-fold (1.01 log units) below it, and the stated range ends below it.
By their numbers in this assay, from the lowest: compound 1; then compound 2; then compound 3.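

In this assay, the group on the aromatic carbon para to a large group clearly matters: methoxy in place of fluoro gives an 8.5-fold higher number from compound 1 to compound 3 (0.93 log units; beyond the scatter), even though the shared core and the rest of the aryl ring stay the same. Replacing the whole ring gave a 4.0-fold higher number from compound 1 to compound 2 (0.60 log units; beyond the scatter), so a full ring swap is not needed to move the number well beyond the scatter, and exchanging one small group at this position is enough; among these three compounds, compound 1 keeps the lowest number. Nothing here measures why methoxy gives a higher number than fluoro, so the result stands as an observation without an explanation.

With only fluoro and methoxy at this position, the compounds shown leave open whether fluoro favours a low number or methoxy pushes it up, and a plain hydrogen, a chloro or a methyl group in the same place could help separate the two readings. They also leave open whether the higher number follows the extra heavy atom, the added hydrogen-bond acceptor or something else, which an amine or a longer alkoxy chain at this position could begin to test.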